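The source may report more compounds than this note shows. Statements on the series, on what has been measured and on what is new or still open speak of the compounds shown alone.

Measured compounds, each with its value in an ADME assay on RD cells (Homo sapiens) for cytotoxicity; a higher number here means that more compound is tolerated, a lower number that less compound is tolerated:

Compound 1 `O=C1Nc2ccccc2/C1=N/NC(=S)Nc1ccccc1` gives > 25000 nM, a limit of the assay rather than a number.
Compound 2 `O=C1Nc2ccc(F)cc2/C1=N/NC(=S)Nc1ccccc1` gives > 25000 nM, again a limit.
Compound 3 `Cc1ccc2c(c1)/C(=N/NC(=S)Nc1ccccc1)C(=O)N2` gives > 25000 nM, also a limit.

Compound 1 therefore stands only at the edge of what this assay can report; its two relatives, differing from it by a fluoro or a methyl on an aromatic carbon, sit at the same edge, and the steps a step that the two limits leave unreadable from compound 1 to compound 2, a step that the two limits leave unreadable from compound 1 to compound 3 and a step that the two limits leave unreadable from compound 2 to compound 3 cannot be sized because of the limit of > 25000 nM in this assay, at which 3 of the 3 values shown sit.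

Compound 4 `CNC(=S)N/N=C1\C(=O)Nc2ccccc21` is the next compound. It differs from compound 1 in one place: methyl in place of phenyl on an amide-type nitrogen, the change that, cut one bond further out, reads anilino to methylamino. Going by the values given here, none of the measured steps touches this part of the molecule, so they set no direction for it. Since all three measured values are limits, the expected step of a number no higher from compound 1 to compound 4 (the limit leaves the size open) is itself only an expectation that compound 4 stays at that limit. The estimate for compound 4 is 25000 nM, within 10000 nM to 100000 nM.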

Compound 4, half-maximal cytotoxic concentration: > 25000 nM
Compound 4: no number, only a limit; the forecaster's own chance of this, stated with the estimate: 80%; the middle value lies on the limit itself.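

Compound 1 and compound 4 both give only a limit in this assay, so no step between them can be read: the limit of > 25000 nM in this assay, at which 4 of the 4 values shown sit.

The compounds shown leave open the concentration at which any of them harms the cells, and whether methyl in place of phenyl shifts it.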